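Moving the methoxy group on the aryl carbonyl

A few compounds are considered here, and "the series" means these few. Any claim that something is new, unique, unknown or untested is made for them only; others in the source may bear on it.

Compound 1 `CCCCc1ccc2[nH]c(-c3ccc(OC)cc3)c(/C=N/NC(=O)c3ccc(Cl)cc3)c2c1` in a functional assay on MCF7 cells (Homo sapiens) for antiproliferative activity, with a stated time of 5 days (a higher number here means a weaker inhibitor, a lower number a stronger inhibitor), gives 220 nM
Compound 2 `CCCCc1ccc2[nH]c(-c3ccc(OC)cc3)c(/C=N/NC(=O)c3ccc(F)cc3)c2c1` in this assay gives 84 nM
Compound 3 `CCCCc1ccc2[nH]c(-c3ccc(OC)cc3)c(/C=N/NC(=O)c3ccc(OC)cc3)c2c1` in this assay gives 226 nM

On these numbers, the methoxy member is level with the chloro member (a 1.0-fold higher number from compound 1 to compound 3 (0.01 log units; within the scatter)) and clearly higher than the fluoro member (a 2.7-fold higher number from compound 2 to compound 3 (0.43 log units; beyond the scatter)).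

Compound 4 `CCCCc1ccc2[nH]c(-c3ccc(OC)cc3)c(/C=N/NC(=O)c3ccccc3OC)c2c1` carries 2-methoxyphenyl in place of 4-methoxyphenyl on a carbonyl carbon. Among the measured compounds shown here, no measured step moves a group around this aryl ring, so none bears on the change directly. The nearest evidence is the exchange of groups on the same aryl ring, where the fluoro-for-chloro step (a 2.6-fold lower number from compound 1 to compound 2 (0.42 log units; beyond the scatter)) was modest. The data give no firm direction for the move, so only a small lean towards a higher number is expected in this assay, probably no larger than those modest steps. The expected step is an estimated (a 1.3-fold higher number from compound 3 to compound 4 (0.12 log units; within the scatter)). For compound 4 the estimated value is 300 nM, with an expected range from 100 nM to 900 nM.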

Compound 4, half-maximal inhibitory concentration: 71 nM
For compound 4 the middle estimate is 4.2-fold (0.63 log units) above the measured one, and the stated range ends above it.
By their numbers in this assay, from the lowest: compounds 4 and 2 (each within the scatter of the next); then compounds 1 and 3 (each within the scatter of the next).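

Exchanging 4-methoxyphenyl for 2-methoxyphenyl on the carbonyl carbon gives a 3.2-fold lower number from compound 3 to compound 4 (0.50 log units; beyond the scatter) in this assay with the same atoms joined differently, so the place of the methoxy on this aryl ring matters and not only the identity of the group. Against the halogen members, 2-methoxyphenyl gives a 3.1-fold lower number from compound 1 to compound 4 (0.49 log units; beyond the scatter) relative to 4-chlorophenyl, while a 1.2-fold lower number from compound 2 to compound 4 (0.07 log units; within the scatter) leaves it level with 4-fluorophenyl. Nothing at hand accounts for this shift.

Whether a shift of this kind also holds for fluoro or chloro stays open, since the compounds shown carry them only as 4-fluorophenyl and 4-chlorophenyl. Also open, from the compounds shown here alone, is how an amine or a carboxylic acid would read in place of the methoxy of 2-methoxyphenyl.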